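The source may hold more compounds than are shown below. What is called first, only, known or untested is meant among the compounds shown, and "the series" means these compounds.

Measured in a functional assay on SMMC-7721 cells (Homo sapiens) for inhibition, read by MTT assay, with a stated time of 48 h; a higher number here means a weaker inhibitor, a lower number a stronger inhibitor:

- Compound 1 `Nc1n[nH]c2cccc(-c3cccc(NC(=O)Nc4ccc(F)c(F)c4)c3)c12`: 5880 nM
- Compound 2 `Nc1n[nH]c2cccc(-c3cccc(NC(=O)Nc4ccc(Cl)c(C(F)(F)F)c4)c3)c12`: 1150 nM

Compound 2 holds the lower of these two numbers, and its gap to compound 1 lies beyond the scatter of repeated measurements, so compound 2 is the stronger inhibitor of the pair. Compound 3 `Nc1n[nH]c2cccc(-c3cccc(NC(=O)Nc4cccc(C(F)(F)F)c4)c3)c12` has not yet been measured. It differs from compound 2 in one place: hydrogen in place of chloro on an aromatic carbon. Put simply, hydrogen stands in place of chloro on an aromatic carbon. Within the data shown here, no measured pair shows this single change alone, so any forecast is loose. A modest rise in the number in this assay is expected, meaning somewhat weaker inhibition, though the shift may not clear the scatter. The expected change is a 2.1-fold higher number from compound 2 to compound 3 (0.32 log units; beyond the scatter). For compound 3 the estimated value is 2400 nM, with an expected range from 900 nM to 6500 nM.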

Compound 3, half-maximal inhibitory concentration: 1410 nM
Compound 3: the middle estimate sits 1.7-fold (0.23 log units) above what was measured, and the stated range covers the measured number.
By their numbers in this assay, from the lowest: compounds 2 and 3 (each within the scatter of the next); then compound 1.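

Taking the chloro off the aromatic carbon ortho to the trifluoromethyl group gives a 1.2-fold higher number from compound 2 to compound 3 (0.09 log units; within the scatter) in this assay, so at this position hydrogen and chloro cannot be told apart in this assay. Replacing 3,4-difluorophenyl with 3-(trifluoromethyl)phenyl on the amide-type nitrogen gives a 4.2-fold lower number from compound 1 to compound 3 (0.62 log units; beyond the scatter), which shows that the stronger inhibition relative to compound 1 does not depend on the chloro. No measurement here explains either result.

Compound 1 and compound 3 differ in the whole substitution of that ring, so what each fluoro or the trifluoromethyl group contributes on its own remains unresolved. As far as these compounds go, how a methoxy group or an amine on the same aromatic carbon would behave also remains open.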